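A few compounds are considered here, and "the series" means these few. Any claim that something is new, unique, unknown or untested is made for them only; others in the source may bear on it.

Measured so far in a functional assay on the whole organism (artery, strain albino) with Rattus norvegicus as the target, with a stated time of 30 min, at a dose of 10 mg/kg by the oral route; a lower number here means less inhibition, a higher number more inhibition at the dose given (going by the name of the read-out):

- compound 1, `COc1ccc(C2N=C(SCc3ccc(Cl)cc3)NC(C)=C2C(=O)Nc2ccc(F)cc2)cc1OC`, gives 5.7%
- compound 2, `COc1ccc(C2N=C(SCc3ccc(F)cc3)NC(C)=C2C(=O)Nc2ccc(F)cc2)cc1OC`, gives 6.7%
- compound 3, `CC1=C(C(=O)Nc2ccc(Br)cc2)C(c2ccc(Cl)cc2Cl)N=C(SCc2ccc(Cl)cc2)N1`, gives 6.7%

All three numbers sit close together; compound 3 and compound 2 read the same at the digits given, and compound 1 sits within the scatter of both. For the measured compounds named here, the one change seen twice in this set is fluoro in place of chloro on an aromatic carbon, which in this assay made the step of a number 1 percentage points higher from compound 1 to compound 2 (within the scatter). Compound 4, `CC1=C(C(=O)Nc2ccc(Br)cc2)C(c2ccc(Cl)cc2Cl)N=C(SCc2ccc(F)cc2)N1`, carries the same change on the core of compound 3, namely (fluoro in place of chloro on an aromatic carbon), at the same kind of place as before. The difference between the core of compound 3 and that of compound 1 is not broken down here.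

For compound 4 a step of about the size seen from compound 1 to compound 2 is expected, that is a number 0.8 percentage points higher from compound 3 to compound 4 (within the scatter), resting on the step of a number 1 percentage points higher from compound 1 to compound 2 (within the scatter) and on the reading of compound 3, 6.7%. Compound 4 is therefore estimated at 7.5% in this assay, with a range from 0% to 17%.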

Compound 4, a percentage reported as inhibition, in the whole organism at one dose (the size of the read-out at that dose, not a potency): 7.7%
Compound 4: middle estimate off by 0.2 percentage points, on the low side, and the stated range covers the measured number.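

In this assay, going from 4-chlorobenzyl to 4-fluorobenzyl gives a number 1 percentage points higher from compound 3 to compound 4 (within the scatter). The change carries from the core of compound 1 to the core of compound 3 with no visible difference between the two steps: the same change on two cores in this assay, a number 1 percentage points higher (within the scatter) from compound 1 to compound 2 and a number 1 percentage points higher (within the scatter) from compound 3 to compound 4, 0 percentage points apart, within the scatter of two such steps

For the compounds shown here, both steps lie within the scatter, so this shows only that the two cores agree for this change; it does not show that the change itself has any effect, or that the cores would also agree on a change with a larger step.

The compounds shown carry only (4-chlorobenzyl)sulfanyl and (4-fluorobenzyl)sulfanyl at this place. From the compounds shown here alone, how an amine, a carboxylic acid or a longer alkyl chain would read there remains open.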